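The source may hold more compounds than are shown below. What is called first, only, known or untested is meant among the compounds shown, and "the series" means these compounds.

In a physicochemical assay for lipophilicity, at pH 7.4 (on this read-out lower numbers stand for lower lipophilicity and higher numbers for higher lipophilicity), compound 1 `CC(C)CN(c1ccc(N(C)C)cc1)S(=O)(=O)c1ccc2c(c1)C(O)CC(C1CCOCC1)O2` gives 3.51, which places it second highest among the three compounds measured. Compound 2 `O=S(=O)(c1ccc2c(c1)C(O)CC(C1CCOCC1)O2)N1CCCC1c1ccccc1C(F)(F)F` gives 3.41 in this assay, a number that lies within the scatter of the value for compound 1. Compound 3 `CCc1ccc(N(CC(C)C)S(=O)(=O)c2ccc3c(c2)C(O)CC(C(C)C2CCOCC2)O3)cc1` gives 5.04, well beyond the scatter above compound 1. Compound 4 `CC(C)CN(c1ccc(C#N)cc1)S(=O)(=O)c1ccc2c(c1)C(O)CC(C1CCOCC1)O2` has not yet been measured in this assay. It differs from compound 1 in one place: cyano in place of dimethylamino on an aromatic carbon. Among the measured compounds shown here, no measured pair shows this change, so its effect is only expected. A modest step downward is expected, a number 0.71 log units lower from compound 1 to compound 4 (beyond the scatter), larger than the scatter. Compound 4 is therefore expected to give about 2.8, likely between 2.3 and 3.3.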

Compound 4, distribution coefficient: 3.07
Beside the measured number, compound 4's estimate is 0.27 log units below it; the measured number falls inside the stated range.
By their numbers in this assay, from the lowest: compound 4; then compounds 2 and 1 (each within the scatter of the next); then compound 3.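

Among the compounds shown here, at this position, on an aromatic carbon para to a large group, cyano in place of dimethylamino moves the number in this assay by a step beyond the scatter (a number 0.44 log units lower from compound 1 to compound 4 (beyond the scatter)), the first direct reading of a change here. The step comes with no difference in the hydrogen-bond donors, hydrogen-bond acceptors or net charge counted for the two groups. Nothing shown accounts for its size.

The compounds shown leave open how a carboxylic acid or a methoxy group at this position would read. They also leave open whether the same exchange gives a similar step on another core.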